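This account rests on a few compounds, and the source may have more. Where it says the series, first, only, none or still open, it means among the compounds named here.

Measured so far:
compound 1, `CCN(Cc1ccccc1)C(=O)C1CCN(S(=O)(=O)c2ccccc2OC)CC1` — in a functional assay on CHO cells for positive allosteric modulation of muscarinic acetylcholine receptor M5 (Homo sapiens), read by calcium flux (a lower number here means a smaller maximal response, a higher number a larger maximal response), compound 1 gives "not determined" (no result reported)
compound 2, `CCN(Cc1ccc(F)cc1)C(=O)C1CCN(S(=O)(=O)c2ccc3cn[nH]c3c2)CC1` — 55%

Among the measured compounds shown here, compound 2 holds the only number in this assay; compound 1 carries no result there, so compound 2 stands alone, with no comparison possible. Compound 3, `CCN(Cc1ccccc1C(F)(F)F)C(=O)C1CCN(S(=O)(=O)c2ccc3cn[nH]c3c2)CC1`, differs from compound 2 by 2-(trifluoromethyl)phenyl in place of 4-fluorophenyl on a saturated chain carbon bound to an amide-type nitrogen. For the measured compounds named here, no measured step of this kind exists, so the direction is uncertain. The expected step of a number 7 percentage points lower from compound 2 to compound 3 (within the scatter) is small, likely within the usual scatter, with a slight lean downward. Compound 3 is therefore estimated at 48%, with a range from 20% to 80%.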

Compound 3, largest response reached (reported as percent of maximum), in percent of the reference or control that the assay uses: 92%
Beside the measured number, compound 3's estimate is 44 percentage points below it, outside the stated range (above it).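

Among the compounds shown here, the aryl group on a saturated chain carbon bound to an amide-type nitrogen is not a silent position in this assay: 2-(trifluoromethyl)phenyl in place of 4-fluorophenyl gives a number 37 percentage points higher from compound 2 to compound 3 (beyond the scatter) as the first readable step. This one change, with the rest of the molecule held constant, is enough to move the maximal response by a large margin. No data at hand bear on the reason for the gain.

The compounds shown do not separate the trifluoromethyl group from its placement on the ring. On these data alone, how a 2-chlorobenzyl or a 4-(trifluoromethyl)benzyl would read here remains open.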